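Aryl piperazine sulfonamides on a shared xanthine-type core

The source may report more compounds than this note shows. Statements on the series, on what has been measured and on what is new or still open speak of the compounds shown alone.

Compound 1 `CCCn1c(=O)[nH]c2nc(-c3ccc(S(=O)(=O)N4CCN(c5ccccc5C)CC4)cc3)[nH]c2c1=O` gives 419 nM in an assay on CHO cells for displacement of a labelled ligand from adenosine receptor A1 (Homo sapiens), read by scintillation counting, with a stated time of 90 min, in the presence of a further agent that is not named here; a higher number here means a weaker inhibitor, a lower number a stronger inhibitor. Compound 2 `CCCn1c(=O)[nH]c2nc(-c3ccc(S(=O)(=O)N4CCN(c5cccc(Cl)c5)CC4)cc3)[nH]c2c1=O` sits at the limit of this assay, > 1000 nM. Compound 3 `CCCn1c(=O)[nH]c2nc(-c3ccc(S(=O)(=O)N4CCN(c5ccc(C)cc5)CC4)cc3)[nH]c2c1=O` also sits at the limit, > 1000 nM. The steps of an at least 2.3-fold higher number from compound 1 to compound 2 (0.37 log units; beyond the scatter) and an at least 2.3-fold higher number from compound 1 to compound 3 (0.37 log units; beyond the scatter) both show a loss once the 2-methylphenyl is changed, while a step that the two limits leave unreadable from compound 2 to compound 3 stays unreadable because of the limit of > 1000 nM in this assay, at which 2 of the 3 values shown sit. Compound 4 `CCCn1c(=O)[nH]c2nc(-c3ccc(S(=O)(=O)N4CCN(C(C)c5ccccc5)CC4)cc3)[nH]c2c1=O` carries the change (1-phenylethyl in place of 4-methylphenyl on an amine nitrogen in a ring). Going by the values given here, no measured step covers an alkyl-linked phenyl at this position, so the expectation rests only on the reading of compound 3 and on compound 1 at 419 nM. The step is expected to be a step that the limit leaves unreadable from compound 3 to compound 4, direction uncertain. Compound 4 is expected near 1200 nM, between 250 nM and 6000 nM.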

Compound 4, inhibition constant: >= 1000 nM
Compound 4 was reported as a limit (the forecaster's own chance of this, stated with the estimate: 50%); the middle value is on the limit's open side.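

In this assay 1-phenylethyl in place of 2-methylphenyl on the amine nitrogen in a ring gives (an at least 2.3-fold higher number from compound 1 to compound 4 (0.37 log units; beyond the scatter)), so 1-phenylethyl joins 3-chlorophenyl and 4-methylphenyl among the replacements that lose against 2-methylphenyl. Compound 1 remains the only compound shown with a value that is not a limit. The steps to compound 4 from compound 2 and from compound 3 cannot be read because all three values are limits: (the limit of > 1000 nM in this assay, at which 2 of the 4 values shown sit) and (the limit of >= 1000 nM in this assay, at which 1 of the 4 values shown sits).

On these data alone, the order among compound 2, compound 3 and compound 4 stays open. Also open, as far as these compounds go, is how a benzyl group on this nitrogen would compare with the 2-methylphenyl of compound 1 at 419 nM in this assay.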